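The compounds below may be only part of what the source reports. "The series", "measured", "known", "first", "only" and "open" are said of these compounds alone.

Within the data shown here, in a functional assay on K562 cells (Homo sapiens) for antiproliferative activity, read by MTT assay, with a stated time of 48 h (on this read-out lower numbers stand for stronger inhibition and higher numbers for weaker inhibition), compound 2 `Cc1ccc(CN2C(=O)N(c3ccc(Cl)cc3)C(=O)C2CCC(=O)Nc2ccc(C(=O)NO)cc2)cc1` gives 490 nM and sits level with compound 1 `O=C(CCC1C(=O)N(c2ccc(Cl)cc2)C(=O)N1Cc1ccc(Br)cc1)Nc1ccc(C(=O)NO)cc1` at 690 nM on this scale, the only other number so far. Compound 3 `O=C(CCC1C(=O)N(c2ccc(Cl)cc2)C(=O)N1Cc1ccccc1)Nc1ccc(C(=O)NO)cc1` loses one group from compound 2: the change is hydrogen in place of methyl on an aromatic carbon or, in words, hydrogen in place of methyl on an aromatic carbon. Among the measured compounds shown here, one measured step bears on this, made on the same aromatic carbon: a 1.4-fold lower number from compound 1 to compound 2 (0.15 log units; within the scatter) when methyl takes the place of bromo. For the measured compounds named here, that exchange left the number within the usual scatter, yet no measured compound shows what hydrogen does there. Going by the values given here, with only that step to go on, no change beyond the scatter is expected in this assay for compound 3. An estimated 1.1-fold higher number from compound 2 to compound 3 (0.05 log units; within the scatter) is what this expectation comes to. For compound 3 the estimated value is 550 nM with an expected range of 250 nM to 1200 nM across repeat measurements.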

Compound 3, half-maximal inhibitory concentration: 830 nM
Compound 3: the middle estimate sits 1.5-fold (0.18 log units) below what was measured, and the stated range covers the measured number.
By their numbers in this assay, from the lowest: compounds 2, 1 and 3 (each within the scatter of the next).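

In this assay, among these compounds, hydrogen now stands where the earlier compounds carried a substituent, and the comparison gives a 1.7-fold higher number from compound 2 to compound 3 (0.23 log units; within the scatter) for the loss of methyl and a 1.2-fold higher number from compound 1 to compound 3 (0.08 log units; within the scatter) for the loss of bromo. The earlier step only exchanged one substituent for another, whereas these two show that the para position of the benzyl ring can also be left empty without the number moving beyond the usual scatter. So far, hydrogen, methyl and bromo at this position cannot be told apart in this assay, and nothing available bears on the reason.

As far as these compounds go, whether an amine, a carboxylic acid or a longer chain at this position would give a number outside that scatter remains open. The compounds shown also leave open whether other positions on the same ring would respond as little.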